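A Hydroxymethyl in Place of Amino: Expected Cytotoxicity

This account rests on a few compounds, and the source may have more. Where it says the series, first, only, none or still open, it means among the compounds named here.

compound 1, `Nc1cn(COC(CO)CO)c(=O)[nH]c1=O`: > 432000 nM
compound 2, `Cc1cn(COC(CO)CO)c(=O)[nH]c1=O`: > 434000 nM

Both measured compounds share one core and were tested in a functional assay on HepG2 cells (Homo sapiens) for cytotoxicity; on this read-out lower numbers stand for higher toxicity in this test and higher numbers for lower toxicity in this test. In this assay compound 1 gives > 432000 nM, which is a limit of the assay and not a number. Compound 2 gives > 434000 nM, likewise only a limit. For the measured compounds named here, compound 1 therefore stands only at a limit, and the one further value shown is also a limit. Going by the values given here, the single measured step, a step that the two limits leave unreadable from compound 1 to compound 2, has no readable size because the limit of > 432000 nM in this assay, at which 1 of the 2 values shown sits, and the limit of > 434000 nM in this assay, at which 1 of the 2 values shown sits, are both limits; the methyl in place of amino on an aromatic carbon cannot be assigned any effect from them.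

Compound 3, `O=c1[nH]c(=O)n(COC(CO)CO)cc1CO`, differs from compound 1 as follows: hydroxymethyl in place of amino on an aromatic carbon. The measured step bears on this change only in that neither measured compound reached a numerical value in this assay. No step beyond the scatter is therefore expected, and compound 3 is expected to sit at or near the same limit. The estimate for compound 3 in this assay is 430000 nM, with a range from 200000 nM to 600000 nM, an expected step of a number no higher from compound 1 to compound 3 (the limit leaves the size open).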

Compound 3, half-maximal cytotoxic concentration: > 406000 nM
Compound 3: only a limit was reported; the forecaster's own chance of this, stated with the estimate: 85%; the middle value is on the limit's open side.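

In this assay compound 3 gives > 406000 nM, which is a limit of the assay and not a number. The steps from compound 1 and from compound 2 to compound 3 therefore cannot be read. The compounds shown leave open whether amino, methyl or hydroxymethyl on this aromatic carbon makes any difference in this assay.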